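Swapping 4-methylphenyl for hydrogen in compound 1

The source may report more compounds than this note shows. Statements on the series, on what has been measured and on what is new or still open speak of the compounds shown alone.

Within the data shown here, in a functional assay on HepG2 cells (Homo sapiens) for antiproliferative activity, read by MTT assay, with a stated time of 72 h (a lower number here means a stronger inhibitor, a higher number a weaker inhibitor), compound 1 `COc1ncc(-c2ccc3c(c2)N(c2ccc(C)cc2)C(=O)CO3)cc1NS(=O)(=O)c1ccc(F)cc1` gives 28300 nM and stands highest of the two numbers so far. Compound 2 `COc1ccc(N2C(=O)COc3ccc(-c4ccc(O)cc4)cc32)cc1` gives 10800 nM and lies lower, beyond the scatter. Compound 3 `COc1ncc(-c2ccc3c(c2)NC(=O)CO3)cc1NS(=O)(=O)c1ccc(F)cc1` carries hydrogen in place of 4-methylphenyl on an amide-type nitrogen in a ring and has not yet been measured. Among the measured compounds shown here, no measured pair isolates this change, so any forecast is uncertain. In this assay the expected step of a 1.3-fold lower number from compound 1 to compound 3 (0.11 log units; within the scatter) stays within the scatter, with no clear direction. Compound 3 is estimated at 22000 nM with an expected span from 6000 nM to 70000 nM as the likely range.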

Compound 3, half-maximal inhibitory concentration: 6590 nM
For compound 3 the middle estimate is 3.3-fold (0.52 log units) above the measured one; measured number inside the range.
By their numbers in this assay, from the lowest: compounds 3 and 2 (each within the scatter of the next); then compound 1.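

In this assay, among these compounds, the first matched step at this position shows that replacing 4-methylphenyl with hydrogen on the amide-type nitrogen in a ring gives a 4.3-fold lower number from compound 1 to compound 3 (0.63 log units; beyond the scatter), so this aryl group is not required for the activity seen here. No measurement shown explains this gain.

From the compounds shown here alone, whether a methyl group or a short chain ending in an amine on that nitrogen would stand nearer compound 3 or compound 1 remains open. So does whether the same change would have a similar effect in compound 2.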